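A phenyl swap on a compound at the limit

The compounds below may be only part of what the source reports. "The series", "measured", "known", "first", "only" and "open" are said of these compounds alone.

Measured in a functional assay on K562 cells (Homo sapiens) for inhibition, read by trypan blue exclusion, with a stated time of 48 h; a lower number here means a stronger inhibitor, a higher number a weaker inhibitor:
Compound 1 `Cc1ccc(NC(=O)/C=C/c2ccccc2)c(C(N)=O)c1` gives 5500 nM
Compound 2 `Cc1ccc(/C=C/C(=O)Nc2ccc(Cl)cc2C(N)=O)cc1` gives 6300 nM
Compound 3 `NC(=O)c1cc(Br)ccc1NC(=O)/C=C/c1cccc(Cl)c1` gives > 10000 nM

Compound 1 and compound 2 sit within the usual scatter of each other. Compound 3 reads > 10000 nM in this assay as a limit of the assay and not a number. Compound 3 therefore stands at the limit of > 10000 nM in this assay, at which 1 of the 3 values shown sits, and has no exact value to start from.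

Compound 4 `Cc1ccccc1/C=C/C(=O)Nc1ccc(Br)cc1C(N)=O` keeps the shared core but carries 2-methylphenyl in place of 3-chlorophenyl on a double-bonded chain carbon bound to a double-bonded chain carbon. For the measured compounds named here, no measured pair isolates this change, so any forecast is rough. Compound 2 also has a methyl-bearing phenyl group and gives 6300 nM in this assay, which points to an exact number for compound 4 as well. The expected change, an at least 1.4-fold lower number from compound 3 to compound 4 (0.15 log units; that floor lies within the scatter), is a modest gain in strength, though another reading at the limit remains possible. For compound 4 the estimated value is 7000 nM, with an expected range of 2500 nM to 15000 nM in this assay.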

Compound 4, half-maximal inhibitory concentration: > 10000 nM
Compound 4: a limit, no number; the forecaster's own chance of this, stated with the estimate: 35%; middle value at least 1.4-fold (0.15 log units) away from the limit.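

Compound 3 and compound 4 each read as a limit in this assay and not as a number, so no step between them can be read: the limit of > 10000 nM in this assay, at which 2 of the 4 values shown sit.

Going by these compounds, whether 2-methylphenyl in place of 3-chlorophenyl changes the strength of inhibition at all stays open.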